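The source may report more compounds than this note shows. Statements on the series, on what has been measured and on what is new or still open speak of the compounds shown alone.

Measured in an ADME assay on cells (Homo sapiens) for antiproliferative activity, read by MTT assay; on this read-out lower numbers stand for stronger inhibition and higher numbers for weaker inhibition:
- Compound 1 `O=C(N/N=C/c1ccccn1)c1ccc(O)cc1`: > 80000 nM
- Compound 2 `C/C(=N\NC(=O)c1ccc([N+](=O)[O-])cc1)c1cnccn1`: 1390 nM

Compound 1 stands at a limit of this assay, not at a number: the limit of > 80000 nM in this assay, at which 1 of the 2 values shown sits. Compound 3 `O=C(N/N=C/c1ccccn1)c1ccc(C(F)(F)F)cc1` keeps the core of compound 1 and has trifluoromethyl in place of hydroxy on an aromatic carbon, para to a large group (trifluoromethyl in place of hydroxy on an aromatic carbon). The expected step of an at least 5.3-fold lower number from compound 1 to compound 3 (0.72 log units; beyond the scatter) is towards stronger inhibition and beyond the scatter, though its size is poorly fixed. Compound 2 gives 1390 nM, so this assay does return numbers for this series. For compound 3 the estimated value is 15000 nM, with an expected range of 2500 nM to 80000 nM.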

Compound 3, half-maximal inhibitory concentration: 22400 nM
Compound 3: middle estimate off by 1.5-fold (0.17 log units), on the low side; the measured number falls inside the stated range.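

At this position, on an aromatic carbon para to a large group, trifluoromethyl in place of hydroxy moves the core of compound 1 from a limit to a measurable number in this assay, giving an at least 3.5-fold lower number from compound 1 to compound 3 (0.55 log units; beyond the scatter). The direction of this step is therefore fixed, but its size is only a lower bound. Compound 1 stands at a limit, not at a number: the limit of > 80000 nM in this assay, at which 1 of the 3 values shown sits.

Going by these compounds, whether the step follows from the loss of hydroxy or from the entry of trifluoromethyl stays open. An amine, a methoxy group or a chlorine atom at this position would help separate the two.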